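Benzyloxy aryl substituent variation in a bis-ether amine series

The compounds below may be only part of what the source reports. "The series", "measured", "known", "first", "only" and "open" are said of these compounds alone.

Measured so far:
compound 1 `COc1cccc(OC)c1OCCNCCOc1ccccc1OCc1cccc(C)c1`: 0.251 nM
compound 2 `COc1cccc(OC)c1OCCNCCOc1ccccc1OCc1cccc([N+](=O)[O-])c1`: 0.794 nM
compound 3 `COc1cccc(OC)c1OCCNCCOc1ccccc1OCc1ccc([N+](=O)[O-])cc1`: 0.398 nM

In an assay on CHO cells for displacement of a labelled ligand from Alpha-1B adrenergic receptor (Homo sapiens) (on this read-out lower numbers stand for stronger inhibition and higher numbers for weaker inhibition), compound 3 gives 0.398 nM, the second highest of the three numbers; its nearest neighbour is compound 1, and compound 2 is the furthest, both within the scatter of compound 3.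

Compound 4 `COc1cccc(COc2ccccc2OCCNCCOc2c(OC)cccc2OC)c1` carries 3-methoxyphenyl in place of 4-nitrophenyl on a saturated chain carbon bound to an oxygen on an aromatic ring.

Among the measured compounds shown here, three measured steps bear on this change. The step of a 1.6-fold higher number from compound 1 to compound 3 (0.20 log units; within the scatter) and the step of a 2.0-fold lower number from compound 2 to compound 3 (0.30 log units; within the scatter) both swap one substituted phenyl on this carbon for another and stay within the scatter. The step of a 3.2-fold higher number from compound 1 to compound 2 (0.50 log units; beyond the scatter), nitro in place of methyl, is the only one beyond the scatter, and it runs from the methyl compound to the nitro compound. For the measured compounds named here, no compound with a methoxy group on this ring has been measured, so the size of the move to methoxy rests on analogy with methyl alone.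

Expectation for compound 4: a small step in this assay, a 1.3-fold lower number from compound 3 to compound 4 (0.12 log units; within the scatter), likely within the scatter, since the closest comparison, compound 1 at 0.251 nM, differs little from compound 3. Compound 4 is therefore estimated at 0.3 nM, with a range of 0.1 nM to 1 nM.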

Compound 4, inhibition constant: 2 nM
Compound 4: middle estimate off by 6.7-fold (0.82 log units), on the low side; the measured number lies above the stated range.
By their numbers in this assay, from the lowest: compounds 1, 3 and 2 (each within the scatter of the next, the first and the last beyond it); then compound 4.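

In this assay, the 3-methoxyphenyl group separates from all three earlier benzyloxy variants, with a 5.0-fold higher number from compound 3 to compound 4 (0.70 log units; beyond the scatter), a 2.5-fold higher number from compound 2 to compound 4 (0.40 log units; beyond the scatter) and an 8.0-fold higher number from compound 1 to compound 4 (0.90 log units; beyond the scatter), which makes compound 4 the weakest of the four. Methyl therefore proved a poor guide to methoxy at this place: this swap gives the largest step in the set, and methoxy also stands beyond the scatter of both nitro compounds. No measured property is available to account for the methoxy result.

On these data alone, whether the loss belongs to methoxy alone or extends to other oxygen-linked groups stays open. It is also unknown whether a hydroxyl, an ethoxy or an amine on this ring would stay close to compound 1 or move towards compound 4.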